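Removing one pivalate ester from the shared core

The compounds below may be only part of what the source reports. "The series", "measured", "known", "first", "only" and "open" are said of these compounds alone.

Measured compounds:
Compound 1, `CC(C)=CCC[C@H](C)[C@H]1c2cc(C(=O)NCc3ccc(Cl)cc3)c(OC(=O)C(C)(C)C)c(OC(=O)C(C)(C)C)c2[C@H](C)C[C@H]1OC(=O)C(C)(C)C`: 40000 nM
Compound 2, `CC(C)=CCC[C@H](C)[C@H]1c2cc(C(=O)NCc3ccc(F)cc3)c(OC(=O)C(C)(C)C)c(OC(=O)C(C)(C)C)c2[C@H](C)C[C@H]1OC(=O)C(C)(C)C`: 80000 nM
Compound 3, `CC(C)=CCC[C@H](C)[C@H]1c2cc(C(=O)O)c(OC(=O)C(C)(C)C)c(OC(=O)C(C)(C)C)c2[C@H](C)C[C@H]1OC(=O)C(C)(C)C`: 40000 nM

In an ADME assay on HEK293 cells (Homo sapiens) for inhibition, read by resazurin assay, with a stated time of 72 h (a higher number here means a weaker inhibitor, a lower number a stronger inhibitor), compound 3 gives 40000 nM. Compound 1 sits level with it, no change at the digits printed from compound 1 to compound 3 (within the scatter), and the step to compound 2 is also within the scatter, a 2.0-fold lower number from compound 2 to compound 3 (0.30 log units; within the scatter). The three measured compounds differ only at the carbonyl carbon, where a carboxylic acid, a (4-chlorobenzyl)amino group or a (4-fluorobenzyl)amino group sits, and none of these exchanges moves the number beyond the scatter, a 2.0-fold higher number from compound 1 to compound 2 (0.30 log units; within the scatter) included.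

Compound 4, `CC(C)=CCC[C@H](C)[C@H]1c2cc(C(=O)O)c(OC(=O)C(C)(C)C)c(OC(=O)C(C)(C)C)c2[C@H](C)C[C@H]1O`, departs from compound 3 elsewhere: hydrogen in place of (tert-butyl)carbonyl on an oxygen on a saturated carbon. Among the compounds with values here, no measured pair shows this change, so none of the steps bears directly on it. What the measured compounds do show is that the numbers of this series are clustered tightly, with every step within the scatter. On that basis the expected step in this assay is no change at the digits printed from compound 3 to compound 4 (within the scatter), that is, no movement beyond the scatter in either direction. Compound 4 is therefore estimated at 40000 nM, with a range from 15000 nM to 100000 nM.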

Compound 4, half-maximal inhibitory concentration: 40000 nM
Estimate against measurement, compound 4: no gap at the digits printed, within the range that was stated.
By their numbers in this assay, from the lowest: compounds 1, 3, 4 and 2 (each within the scatter of the next).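

Within the data shown here, until now the series had varied only the group on the carbonyl carbon, so compound 4 gives the first reading at a second place, the oxygen on a saturated carbon whose other neighbour is a saturated ring carbon. In this assay, replacing the (tert-butyl)carbonyl on that oxygen with hydrogen, which turns the ((tert-butyl)carbonyl)oxy group into hydroxy and takes away 6 heavy atoms, gives no change at the digits printed from compound 3 to compound 4 (within the scatter). The insensitivity seen so far at the carbonyl carbon therefore also holds for this one exchange at the oxygen, though only with the carboxylic acid in place, and nothing at hand accounts for it.

The compounds shown leave open whether the same exchange would read alike with the (4-chlorobenzyl)amino or (4-fluorobenzyl)amino group on the carbonyl carbon, as in the amides compound 1 and compound 2. They also leave open what an acetyl or a methyl on this oxygen would give, and what would follow if the two remaining pivalate esters were replaced by hydroxy groups.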